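The source may hold more compounds than are shown below. What is called first, only, known or untested is meant among the compounds shown, and "the series" means these compounds.

Two compounds of one series have been examined in an ADME assay on Vero cells (Chlorocebus sabaeus) for cytotoxicity, with a stated time of 72 h, tested at 10 ug/mL; on this read-out lower numbers stand for a weaker effect and higher numbers for a stronger effect at the one concentration tested. Compound 1, `N=c1c(=O)[nH]nc2n1CCN2c1cccc(Cl)c1`, carries a chloro group on a six-membered aromatic ring of carbon only, and in this assay compound 1 gives 0%. Compound 2, `N=c1c(=O)[nH]nc2n1CCN2c1ccccc1Cl`, is a positional isomer of compound 1 bearing the same chloro group, and in this assay compound 2 gives 0%. Compound 2 thus stands level with compound 1 at the digits recorded; its nearest measured neighbour is compound 1, with no change at those digits, and the two values lie within the scatter of one another.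

Compound 3, `N=c1c(=O)[nH]nc2n1CCN2c1ccccc1`, has not yet been measured in this assay. Its difference from compound 2 is hydrogen in place of chloro on an aromatic carbon. Within the data shown here, no step between two measured compounds describes such a change, so the expectation rests on the two measured values alone: compound 1 and compound 2 both show no effect at the concentration tested, and removal of the chloro group is expected to bring no step beyond the scatter. The estimated step is no change at the digits printed from compound 2 to compound 3 (within the scatter). Compound 3 is accordingly expected to give 0% in this assay, within a range of 0% to 10%.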

Compound 3, a percentage reported as inhibition, at one concentration (the size of the read-out at that concentration, not a potency): 26%
Compound 3: middle estimate off by 26 percentage points, on the low side, and the stated range ends below it.
By their numbers in this assay, from the lowest: compounds 1 and 2 (each within the scatter of the next); then compound 3.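

In this assay the chloro group turns out to count: hydrogen in its place on an aromatic carbon gives a number 26 percentage points higher from compound 2 to compound 3 (beyond the scatter) and, read from the other chloro isomer, a number 26 percentage points higher from compound 1 to compound 3 (beyond the scatter) with each step beyond the scatter. The two chloro compounds alone had shown only that the two places of the group give the same read-out at the digits recorded, whereas these steps separate compound 3, which has no chloro group, from both of them. The steps tie the difference to this one exchange on the ring, but nothing measured alongside them speaks to how it arises.

The compounds shown leave open whether the read-out follows the loss of chlorine itself or would also stay low with another group at the same aromatic carbon, such as fluoro, methyl or methoxy. They also leave open whether compound 3 differs from the chloro compounds only at the one concentration tested, and whether an amine or a carboxylic acid on the ring would lie nearer compound 3 or the chloro compounds.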